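The compounds below may be only part of what the source reports. "The series", "measured", "known", "first", "only" and "open" are said of these compounds alone.

Compound 1, `CC1(C)CCOc2ccc(NC(=S)Nc3ccc(OC(F)(F)F)cc3)cc21`, carries a trifluoromethoxy group. Among the measured compounds shown here, in a functional assay on A2780 cells (Homo sapiens) for inhibition, with a stated time of 72 h, tested at 10 uM (a lower number here means less inhibition of growth, a higher number more inhibition of growth at the concentration tested), compound 1 gives 16%, the lowest of the two numbers measured so far. Compound 2, `CC1(C)CC(C)(C)c2cc(NC(=O)Nc3ccc(C(F)(F)F)cc3)ccc2O1`, gives 88.4% in this assay; the two compounds differ in several places at once, so their values can only be set side by side, and the gap cannot be traced to any single change. Compound 3, `CC1(C)CCOc2ccc(NC(=S)Nc3ccc(C(F)(F)F)cc3)cc21`, is the closest relative of compound 1: the difference is trifluoromethyl in place of trifluoromethoxy on an aromatic carbon. For the measured compounds named here, no measured pair shows this change on its own, so the size of the step is open. Because compound 2 carrying trifluoromethyl shows 88.4%, a move upward is expected, though only a modest one given the other differences between that compound and compound 1. The expected step from compound 1 to compound 3 is a number 16 percentage points higher from compound 1 to compound 3 (beyond the scatter). Compound 3 is estimated to give 32% in this assay, with a range from 10% to 62%.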

Compound 3, percent growth inhibition at one concentration: 28%
Compound 3: the middle estimate sits 4 percentage points above what was measured; the range from low to high includes it.
By their numbers in this assay, from the lowest: compound 1; then compound 3; then compound 2.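

In this assay, putting trifluoromethyl in place of trifluoromethoxy on the aromatic carbon para to a large group gives a number 12 percentage points higher from compound 1 to compound 3 (beyond the scatter) for a single change on an otherwise identical structure. Among the compounds shown here, this is the first direct reading of this position: the group here does affect growth inhibition, and the step is modest in size. Compound 3 remains a weak inhibitor at the concentration tested, so this swap alone does not turn the core of compound 1 into a strong one. Nothing shown explains why the number rises. Also open, going by these compounds, is how this position would respond to a quite different group, such as an amine, a carboxylic acid or a longer alkyl chain, and whether the same swap would give a similar step on another core.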